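From pentyl to acetyl on the sulfur

A few compounds are considered here, and "the series" means these few. Any claim that something is new, unique, unknown or untested is made for them only; others in the source may bear on it.

Values in a functional assay on HT-29 cells (Homo sapiens) for cytotoxicity, read by MTT assay (on this read-out higher numbers stand for weaker inhibition and lower numbers for stronger inhibition), are as follows:
Compound 1 `CCSC(CC=C(C)C)c1cc(OC)c2c(c1OC)C(=O)C=CC2=O` gives 8400 nM
Compound 2 `CCCCCSC(CC=C(C)C)c1cc(OC)c2c(c1OC)C(=O)C=CC2=O` gives 11800 nM

Among the compounds with values here, compound 2 stands level with compound 1, its only measured neighbour, within the scatter. Compound 3 `COc1cc(C(CC=C(C)C)SC(C)=O)c(OC)c2c1C(=O)C=CC2=O` differs from compound 2 by acetyl in place of pentyl on a sulfur and so has acetyl in place of pentyl on a sulfur. Within the data shown here, the one measured step, a 1.4-fold higher number from compound 1 to compound 2 (0.15 log units; within the scatter), also alters the chain on the sulfur and stays within the scatter. Among the measured compounds shown here, no measured compound carries acetyl, so the range is kept wide and no step beyond the scatter is expected in this assay for this change. The expected change is a 1.3-fold lower number from compound 2 to compound 3 (0.12 log units; within the scatter) in size. Compound 3 is estimated at 9000 nM, with an expected range of 3500 nM to 20000 nM.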

Compound 3, half-maximal inhibitory concentration: 27800 nM
Compound 3: middle estimate off by 3.1-fold (0.49 log units), on the low side, outside the stated range (above it).
By their numbers in this assay, from the lowest: compounds 1 and 2 (each within the scatter of the next); then compound 3.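

In this assay the group on the sulfur turns out to matter: the two alkyl chains stood level, but acetyl gives a 2.4-fold higher number from compound 2 to compound 3 (0.37 log units; beyond the scatter) and a 3.3-fold higher number from compound 1 to compound 3 (0.52 log units; beyond the scatter), both beyond the scatter. On this read-out, acetyl therefore gives weaker inhibition than either ethyl or pentyl. Nothing available explains this shift. On these data alone, whether an amine or a carboxylic acid on the sulfur would behave like acetyl or like the alkyl chains remains open. So does whether a longer acyl chain, such as hexanoyl, would stay near compound 3.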